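The source may hold more compounds than are shown below. What is called first, only, known or untested is meant among the compounds shown, and "the series" means these compounds.

Working notes on the series in a functional assay on HL-60 cells (Homo sapiens) for inhibition, read by CCK-8 assay, with a stated time of 48 h; a higher number here means a weaker inhibitor, a lower number a stronger inhibitor.

Compound 1 `Cc1ccc(-c2ccsc2S(=O)(=O)NCCNC(=O)Nc2cccc([N+](=O)[O-])c2)c(Oc2ccc(O)c(O)c2)c1` gives 6000 nM in this assay. Among the two numbers available it is the lowest, and compound 2 `CC(C)c1ccc(Oc2ccc(O)c(O)c2)c(-c2ccsc2S(=O)(=O)NCCNC(=S)Nc2cc(C(F)(F)F)cc(C(F)(F)F)c2)c1`, which gives 8200 nM in this assay, sits within the usual scatter of it, so no order between the two can be read. Compound 3 `COc1ccc(Oc2ccccc2-c2ccsc2S(=O)(=O)N2CCN(C(=O)Nc3cccc([N+](=O)[O-])c3)CC2)cc1OC` gives only a limit in this assay, > 50000 nM, and no number. Among the measured compounds shown here, the limit of > 50000 nM in this assay, at which 1 of the 3 values shown sits, is the only evidence available on the measured compounds; no single-point step between them is available, since each differs from the others in several places at once.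

Compound 4 `Cc1ccc(-c2ccsc2S(=O)(=O)NCCNC(=O)Nc2cc(Cl)cc(Cl)c2)c(Oc2ccc(O)c(O)c2)c1` is not yet measured in this assay. It differs from compound 1 by 3,5-dichlorophenyl in place of 3-nitrophenyl on an amide-type nitrogen. Compound 2 carries a different aryl group on a thiourea-type nitrogen and a different substituent on the shared core, so its value cannot be set against compound 1 as a step for this change. For the measured compounds named here, with no measured step to anchor the change, the expected step from compound 1 to compound 4 is no change at the digits printed from compound 1 to compound 4 (within the scatter), not beyond the scatter in either direction. Compound 4 is therefore estimated at 6000 nM in this assay, with a range from 2500 nM to 15000 nM.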

Compound 4, half-maximal inhibitory concentration: 3500 nM
Compound 4: the middle estimate sits 1.7-fold (0.23 log units) above what was measured; the range from low to high includes it.
By their numbers in this assay, from the lowest: compounds 4, 1 and 2 (each within the scatter of the next, the first and the last beyond it). At a limit, above all of these: compound 3.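

In this assay, the group on the amide-type nitrogen now has its first single-place comparison, a 1.7-fold lower number from compound 1 to compound 4 (0.23 log units; within the scatter). The earlier compounds shown here could not give such a comparison. Each of them differed from the others in several places at once. At this position, 3,5-dichlorophenyl can therefore stand in place of 3-nitrophenyl without a change that can be read, even though the entering group has no hydrogen-bond acceptors and the leaving group has them, so those acceptors are not required for a value in this range within this pair. No measured property bears on this step, and nothing can be said about its cause.

As far as these compounds go, it remains open whether a different kind of group on this nitrogen, such as an aminophenyl, a carboxylic acid-bearing phenyl or a saturated cyclohexyl ring, would move the number beyond the scatter. Compound 3 remains a limit, > 50000 nM, and since it differs from the other compounds in several places, the compounds shown do not tell which of those differences goes with that limit.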